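The compounds below may be only part of what the source reports. "The series", "measured", "known", "first", "only" and "open" are said of these compounds alone.

Measured in a functional assay on U-937 cells (Homo sapiens) for cytotoxicity, read by MTT assay, with a stated time of 3 days; on this read-out lower numbers stand for stronger inhibition and higher numbers for weaker inhibition:
Compound 1 `N#Cc1c(Nc2ccccn2)nc(SCc2nc3ccccc3[nH]2)nc1-c1ccccc1`: 2.55 nM
Compound 2 `N#Cc1c(Nc2nccs2)nc(SCc2nc3ccccc3[nH]2)nc1-c1ccccc1`: 3.8 nM
Compound 3 `N#Cc1c(NC(N)=S)nc(SCc2nc3ccccc3[nH]2)nc1-c1ccccc1`: 20 nM

Among these three, compound 3 has the highest number at 20 nM, so it is the weakest of the set. For the measured compounds named here, compound 4 `N#Cc1c(NC(N)=O)nc(SCc2nc3ccccc3[nH]2)nc1-c1ccccc1` keeps the shared core and changes only one group: a group of 3 heavy atoms (1 carbon, 1 nitrogen, 1 oxygen; no ring) in place of a group of 3 heavy atoms (1 carbon, 1 nitrogen, 1 sulfur; no ring), on a nitrogen on an aromatic ring. The new group, carbamoyl, sits on a nitrogen on an aromatic ring, the same place where compounds 1, 2 and 3 differ. The measured steps at that place are a 1.5-fold higher number from compound 1 to compound 2 (0.17 log units; within the scatter), a 7.8-fold higher number from compound 1 to compound 3 (0.89 log units; beyond the scatter) and a 5.3-fold higher number from compound 2 to compound 3 (0.72 log units; beyond the scatter). The last two are modest, and both replace a ring with a group that has none. Going by the values given here, none of these steps swaps sulfur for oxygen, so the data offer no direct precedent. Compound 4 keeps the ringless form of compound 3, so no large step is expected in this assay, and any shift is expected to be small, with no firm direction. The expected step is a 1.3-fold higher number from compound 3 to compound 4 (0.10 log units; within the scatter). For compound 4 the estimated value is 25 nM, with an expected range from 7 nM to 90 nM.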

Compound 4, half-maximal inhibitory concentration: 3.37 nM
For compound 4 the middle estimate is 7.4-fold (0.87 log units) above the measured one; the measured number lies below the stated range.
By their numbers in this assay, from the lowest: compounds 1, 4 and 2 (each within the scatter of the next); then compound 3.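

In this assay the exchange of sulfur for oxygen in the ringless group on the nitrogen is not a silent one: a 5.9-fold lower number from compound 3 to compound 4 (0.77 log units; beyond the scatter) even though the two groups match in heavy-atom count and in hydrogen-bond donors and acceptors. A ring on this nitrogen also proves unnecessary for the low numbers among these compounds, as carbamoyl stays within the scatter of both ring-bearing groups, with a 1.1-fold lower number from compound 2 to compound 4 (0.05 log units; within the scatter) and a 1.3-fold higher number from compound 1 to compound 4 (0.12 log units; within the scatter) as the steps. Nothing at hand bears on the cause of the step between the two ringless groups.

Going by these compounds, it remains open whether a plain amine or an acetyl group on this nitrogen would stay level with carbamoyl. Also open, on these data alone, is whether a methyl group or a longer chain on the carbamoyl nitrogen would keep these numbers.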